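The source may report more compounds than this note shows. Statements on the series, on what has been measured and on what is new or still open speak of the compounds shown alone.

Measured so far, in a functional assay on cells (Lymphocyte, Homo sapiens) for inhibition, read by flow cytometry, using a membrane potential dye, with a stated time of 16 h, tested at 250 nM; on this read-out higher numbers stand for a stronger effect at the one concentration tested and lower numbers for a weaker effect:
- compound 1 `Cc1c(N(C)C)nc(CCCCCCCCCCO)c(O)c1C`: 36%
- compound 2 `CCCCCCCCCCCCCCCCCCCc1nc(N(C)C)c(C)c(C)c1O`: 44%

For the measured compounds named here, compound 2 and compound 1 sit within the scatter of each other; the only measured step, a number 8 percentage points higher from compound 1 to compound 2 (within the scatter), moved the chain end far from the ring without a real change in this assay. Compound 3 `CCCCCCCCCCCCCCCCc1nc(N(C)C)c(C)c(C)c1O` differs from compound 2 by hydrogen in place of propyl on a saturated chain carbon, ten or more bonds along the chain from an aromatic carbon, again at a far chain position. Since that earlier far-chain step stayed within the scatter, no step beyond the scatter is expected here: a number 4 percentage points lower from compound 2 to compound 3 (within the scatter). Compound 3 is estimated at 40%, between 25% and 55%.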

Compound 3, a percentage reported as activity, at one concentration (the size of the read-out at that concentration, not a potency): 84%
The estimate for compound 3 lay 44 percentage points below the measured number; measured number outside the range, above it.
By their numbers in this assay, from the lowest: compounds 1 and 2 (each within the scatter of the next); then compound 3.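

In this assay, a change on a saturated chain carbon can have a large effect: hydrogen in place of propyl gives a number 40 percentage points higher from compound 2 to compound 3 (beyond the scatter), which the earlier step within the scatter gave no sign of. Hexyl in place of hydroxy at this place gives a number 48 percentage points higher from compound 1 to compound 3 (beyond the scatter), so among these three compounds the result depends on exactly which group is swapped in, not merely on the chain being long. Nothing available explains this jump. As far as these compounds go, how a chain shorter or longer than that of compound 3 would read remains open, as does an amine or a carboxylic acid on the chain.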